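This account rests on a few compounds, and the source may have more. Where it says the series, first, only, none or still open, it means among the compounds named here.

Compound 1 `CNC(=O)c1cc(C(=O)NC2CC2)cn(Cc2cccc(OC)c2)c1=O` is the best of three compounds in a physicochemical assay for solubility, read by HPLC, in simulated intestinal fluid, with a stated time of 16 h, tested at 125 ug/mL (a lower number here means a less soluble compound, a higher number a more soluble compound), where compound 1 gives 582 ug/mL. Two changes at the same part of the molecule have already been tried. Compound 2 `CNC(=O)c1cc(C(=O)NC2CC2)cn(Cc2cccc3[nH]ccc23)c1=O` gives 17 ug/mL, and the step of a 34-fold lower number from compound 1 to compound 2 (1.53 log units; beyond the scatter). Compound 3 `CNC(=O)c1cc(C(=O)NC2CC2)cn(Cc2cccc(F)c2)c1=O` gives 31 ug/mL, and the step of a 19-fold lower number from compound 1 to compound 3 (1.27 log units; beyond the scatter). Compound 2 and compound 3 sit close to each other, since a 1.8-fold higher number from compound 2 to compound 3 (0.26 log units; within the scatter).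

Compound 4 `CNC(=O)c1cc(C(=O)NC2CC2)cn(Cc2cccc(C)c2)c1=O` has not yet been measured. Its difference from compound 1 is methyl in place of methoxy on an aromatic carbon. This is the same kind of change as that from compound 1 to compound 3: the methoxy leaves and a group with no hydrogen-bond acceptor enters at the same aromatic carbon. Since both earlier changes from compound 1 gave large drops, a large drop is expected here too, with a step of about a 17-fold lower number from compound 1 to compound 4 (1.22 log units; beyond the scatter). Compound 4 is therefore estimated at 35 ug/mL in this assay, with a likely range from 8 ug/mL to 150 ug/mL.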

Compound 4, solubility: 88 ug/mL
The estimate for compound 4 lay 2.5-fold (0.40 log units) below the measured number, and the stated range covers the measured number.
By their numbers in this assay, from the lowest: compounds 2 and 3 (each within the scatter of the next); then compound 4; then compound 1.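

Methyl in place of methoxy on this aromatic carbon still gives a 6.6-fold lower number from compound 1 to compound 4 (0.82 log units; beyond the scatter) in this assay and leaves compound 1 on top, so a second simple replacement has also failed to match methoxy. The groups that replace it do not all land at one low level, however, as there is a 2.8-fold higher number from compound 3 to compound 4 (0.45 log units; beyond the scatter) and also a 5.2-fold higher number from compound 2 to compound 4 (0.71 log units; beyond the scatter) even though compound 2 and compound 3 lie within the scatter of each other. No measurement here explains this order of groups.

The compounds shown leave open whether an ethoxy group, a hydroxyl or an amine on this aromatic carbon would come close to compound 1, and so whether its high number is particular to methoxy. They also leave open whether the same order of methoxy, methyl and fluoro would hold on a different core.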